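A Five-Membered Heteroaryl Swap on the Amide Nitrogen

The source may hold more compounds than are shown below. What is called first, only, known or untested is meant among the compounds shown, and "the series" means these compounds.

In a functional assay on CHO cells for agonist activity at Free fatty acid receptor 2 (Homo sapiens), read by cAMP accumulation (a lower number here means a stronger inhibitor, a higher number a weaker inhibitor), compound 1 `CC(C)[C@H](C(=O)NC(C)(C)C)c1ccc(Cl)cc1` reaches only a limit, > 100000 nM, which is the limit of > 100000 nM in this assay, at which 1 of the 2 values shown sits. Among the compounds with values here, compound 2 `CC(C)[C@H](C(=O)Nc1ncns1)c1ccc(Cl)cc1` gives 2000 nM in this assay and is the only compound with a true number among the values shown. The step of an at least 50-fold lower number from compound 1 to compound 2 (1.69 log units; beyond the scatter) was large. Compound 3 `CC(C)[C@H](C(=O)Nc1ccon1)c1ccc(Cl)cc1` carries 1,2-oxazol-3-yl in place of 1,2,4-thiadiazol-5-yl on an amide-type nitrogen. Within the data shown here, only the step of an at least 50-fold lower number from compound 1 to compound 2 (1.69 log units; beyond the scatter) bears on this change, yet it exchanged tert-butyl for a heteroaryl, whereas here one five-membered heteroaryl replaces another, so a step no larger than the scatter is expected, a 2.0-fold higher number from compound 2 to compound 3 (0.30 log units; within the scatter). Compound 3 is therefore estimated at 4000 nM, within 1000 nM to 20000 nM.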

Compound 3, half-maximal inhibitory concentration: 36000 nM
Compound 3: middle estimate off by 9.0-fold (0.95 log units), on the low side; the whole stated range lies below it.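

The amide-type nitrogen separates one five-membered heteroaryl from another, not only a heteroaryl from tert-butyl: 1,2-oxazol-3-yl in place of 1,2,4-thiadiazol-5-yl gives an 18-fold higher number from compound 2 to compound 3 (1.26 log units; beyond the scatter). Set against tert-butyl, the same group gives an at least 2.7-fold lower number from compound 1 to compound 3 (0.44 log units; beyond the scatter). That step is a bound and not a measured size, as compound 1 stands at a limit: the limit of > 100000 nM in this assay, at which 1 of the 3 values shown sits.

The two rings differ in more than one atom, so the compounds shown do not tell which atom carries the step. As far as these compounds go, how a phenyl or pyridyl group would read on the same nitrogen stays open.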